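The source may report more compounds than this note shows. Statements on the series, on what has been measured and on what is new or still open speak of the compounds shown alone.

Measured in a functional assay on A549 cells (Homo sapiens) for inhibition, read by MTT assay, with a stated time of 72 h; a lower number here means a stronger inhibitor, a higher number a weaker inhibitor:
- Compound 1 `CC(C)CCN(CCCCCCC(=O)NO)c1ncc(C(=O)NCc2cccnc2)s1`: 19000 nM
- Compound 2 `O=C(CCCCCCCN(Cc1ccc(F)cc1)c1ncc(C(=O)NCCCn2ccnc2)s1)NO`: 6600 nM
- Compound 3 `CC(C)CCN(CCCCCC(=O)NO)c1ncc(C(=O)NCCCn2ccnc2)s1`: 13000 nM

Compound 3 stands within the usual scatter of both compound 1 and compound 2, so this assay does not separate it from either. Compound 4 `CC(C)CCN(CCCCCCC(=O)NO)c1ncc(C(=O)NCCCn2ccnc2)s1` differs from compound 3 in one place: (hydroxycarbamoyl)methyl in place of hydroxycarbamoyl on a saturated chain carbon, five bonds along the chain from a nitrogen on an aromatic ring. Among the compounds with values here, no measured pair of compounds isolates this change, so the data give no direct guide to its effect. With compound 3 at 13000 nM as the starting point, no step beyond the scatter is expected, and the estimated 1.3-fold lower number from compound 3 to compound 4 (0.11 log units; within the scatter) leans only slightly towards a lower number. For compound 4 the estimated value is 10000 nM, with an expected range from 4500 nM to 22000 nM.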

Compound 4, half-maximal inhibitory concentration: 5200 nM
For compound 4 the middle estimate is 1.9-fold (0.28 log units) above the measured one, within the range that was stated.
By their numbers in this assay, from the lowest: compounds 4, 2, 3 and 1 (each within the scatter of the next, the first and the last beyond it).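

In this assay, within the data shown here, (hydroxycarbamoyl)methyl in place of hydroxycarbamoyl on this saturated chain carbon gives a 2.5-fold lower number from compound 3 to compound 4 (0.40 log units; beyond the scatter) and is the only measured step that isolates this change. At the other end of compound 4, 2-(1H-imidazol-1-yl)ethyl in place of pyridin-3-yl on a saturated chain carbon bound to an amide-type nitrogen gives a 3.7-fold lower number from compound 1 to compound 4 (0.56 log units; beyond the scatter) and also lies beyond the scatter. Nothing available here accounts for either step.

The compounds shown leave open how a carboxylic acid in place of the hydroxycarbamoyl group would read in this assay and whether a dimethylamino group could replace the 1H-imidazol-1-yl group.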